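The source may report more compounds than this note shows. Statements on the series, on what has been measured and on what is new or still open speak of the compounds shown alone.

Compound 1 `CCCCN(C)c1nc(C(F)(F)F)ccc1CNC(=O)C(C)c1ccc(NS(C)(=O)=O)c(F)c1` gives 21.3 nM in a functional assay on CHO-K1 cells for antagonist activity at transient receptor potential cation channel subfamily V member 1 (Homo sapiens), read by FLIPR; on this read-out lower numbers stand for stronger inhibition and higher numbers for weaker inhibition. Compound 2 `COC1CCN(c2nc(C(F)(F)F)ccc2CNC(=O)C(C)c2ccc(NS(C)(=O)=O)c(F)c2)CC1` gives 280 nM in this assay.

Within the data shown here, compound 2 stands with the higher of the two numbers in this assay; the only measured step, a 13-fold higher number from compound 1 to compound 2 (1.12 log units; beyond the scatter), exchanges the whole amine and offers no direct precedent for the change now considered. Compound 3 `CCCCOC1CCN(c2nc(C(F)(F)F)ccc2CNC(=O)C(C)c2ccc(NS(C)(=O)=O)c(F)c2)CC1` differs from compound 2 by propyl in place of hydrogen on a saturated chain carbon bound to an oxygen on a saturated carbon. Among the measured compounds shown here, with no step that isolates this kind of chain extension, the expected step of a 1.3-fold lower number from compound 2 to compound 3 (0.10 log units; within the scatter) lies within the scatter. Compound 3 is therefore estimated at 220 nM, with a range from 70 nM to 700 nM in this assay.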

Compound 3, half-maximal inhibitory concentration: 28.2 nM
The estimate for compound 3 lay 7.8-fold (0.89 log units) above the measured number, and the stated range ends above it.
By their numbers in this assay, from the lowest: compounds 1 and 3 (each within the scatter of the next); then compound 2.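

In this assay the change from methoxy to butoxy gives a 9.9-fold lower number from compound 2 to compound 3 (1.00 log units; beyond the scatter) on the same piperidine, so this position on the oxygen is far from indifferent to propyl in place of hydrogen. With butoxy in place, the exchange of the whole amine leaves only a 1.3-fold higher number from compound 1 to compound 3 (0.12 log units; within the scatter) and the two compounds cannot be told apart. Nothing available explains this change in the read-out.

The compounds shown hold only methoxy and butoxy, so it stays open whether ethoxy or a longer chain such as hexyloxy would follow the same direction. As far as these compounds go, whether a terminal amine or phenyl on that chain would be accepted also stays open.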